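The source may hold more compounds than are shown below. What is called first, only, known or untested is meant among the compounds shown, and "the series" means these compounds.

Measured in a functional assay for agonist activity at Free fatty acid receptor 1 (Homo sapiens), read by FLIPR, in the presence of a further agent that is not named here; a lower number here means that less compound is needed, a higher number that more compound is needed for the effect:
- compound 1 `O=C1NC(=O)C(Cc2ccc(Oc3ccc(C(F)(F)F)cn3)cc2)S1` gives 558 nM
- compound 2 `O=C1NC(=O)C(Cc2ccc(Oc3ncc(C(F)(F)F)cc3Cl)cc2)S1` gives 69 nM

Among the compounds with values here, compound 2 holds the lower of the two numbers in this assay; the only step on record, an 8.1-fold lower number from compound 1 to compound 2 (0.91 log units; beyond the scatter), is beyond the scatter and concerns chloro in place of hydrogen on the other aromatic ring.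

Compound 3 `COc1cc(Oc2ncc(C(F)(F)F)cc2Cl)ccc1CC1SC(=O)NC1=O` is not yet measured. Its change from compound 2 is methoxy in place of hydrogen on an aromatic carbon. Within the data shown here, no measured step touches this carbon ring or a methoxy group, so the chloro step gives no guide to size or direction here. In the absence of any bearing step, the expectation is a change within the scatter, written as a 1.1-fold lower number from compound 2 to compound 3 (0.03 log units; within the scatter).

Compound 3 is therefore estimated at 65 nM in this assay, with a range of 20 nM to 220 nM.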

Compound 3, half-maximal effective concentration: 13900 nM
Compound 3: the middle estimate sits 210-fold (2.33 log units) below what was measured; measured number outside the range, above it.
By their numbers in this assay, from the lowest: compound 2; then compound 1; then compound 3.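

In this assay, this carbon of the six-membered aromatic ring of carbon only, ortho to the (2,4-dioxo-1,3-thiazolidin-5-yl)methyl group, proves highly sensitive to substitution: methoxy in place of hydrogen gives a 200-fold higher number from compound 2 to compound 3 (2.30 log units; beyond the scatter). The earlier step, an 8.1-fold lower number from compound 1 to compound 2 (0.91 log units; beyond the scatter), lay on the other aromatic ring and ran in the opposite direction, so a gain from substitution there does not carry over to this carbon. No evidence at hand accounts for the size of this change.

A single substituent at one carbon leaves open whether the loss is specific to methoxy or would also follow from a fluorine atom, a methyl group or a hydroxyl group there. Also open, on these data alone, is how methoxy would behave on the other carbons of this ring.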